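A Bulkier Ether on the Quinoline-Free Core of Compound 1

The compounds below may be only part of what the source reports. "The series", "measured", "known", "first", "only" and "open" are said of these compounds alone.

Compound 1 `COc1ccc2ncc(-c3nn[nH]n3)cc2c1` is tested in a functional assay on the whole organism (strain Sprague-Dawley) for inhibition, with Rattus norvegicus as the target (on this read-out higher numbers stand for an effect only at larger amounts of compound and lower numbers for an effect already at smaller amounts), where compound 1 gives 10 mg/kg. Among the two compounds with a plain number in this assay, compound 1 has the higher one; compound 2 `CCc1cccc2cc(-c3nn[nH]n3)cnc12` gives 2.5 mg/kg, a gap beyond the usual scatter. Compound 3 `COc1ccc2ncc(C(=O)O)cc2c1` gives only a limit in this assay, > 5 mg/kg. The step that the limit leaves unreadable from compound 1 to compound 3 therefore cannot be sized. Compound 4 `c1cc2ncc(-c3nn[nH]n3)cc2cc1OC1CCCCC1` differs from compound 1 by cyclohexyl in place of methyl on an oxygen on an aromatic ring. Among the measured compounds shown here, no measured step touches this ether, and the one measured step concerns another part of the core and is unreadable, so no direction can be drawn from it. Compound 4 is expected to give 10 mg/kg in this assay, between 3 mg/kg and 30 mg/kg, an expected step of no change at the digits printed from compound 1 to compound 4 (within the scatter) within the scatter.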

Compound 4, minimum effective dose: 5 mg/kg
Compound 4: middle estimate off by 2.0-fold (0.30 log units), on the high side; measured number inside the range.
By their numbers in this assay, from the lowest: compounds 2, 4 and 1 (each within the scatter of the next, the first and the last beyond it).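

Cyclohexyl in place of methyl on an oxygen on an aromatic ring gives a 2.0-fold lower number from compound 1 to compound 4 (0.30 log units; within the scatter) in this assay, so the two compounds cannot be told apart here, although cyclohexyl brings 6 heavy atoms where methyl had 1 heavy atom. This is the first readable step at this ether, which no earlier pair touched, and nothing shown gives a cause for the result.

Still open, from the compounds shown here alone, is how this ether position would read with a longer chain such as hexyl, or with an amine or a carboxylic acid at the end of such a chain.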